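The compounds below may be only part of what the source reports. "The series", "measured", "known", "first", "only" and "open" are said of these compounds alone.

Compound 1 `N#Cc1ccc(-c2cnc3[nH]cc(-c4nnc(-c5ccc(F)cc5)o4)c(=O)c3c2)cc1` gives 10.2% in a functional assay on HCT-116 cells (Homo sapiens) for inhibition, read by MTT assay, with a stated time of 24 h, tested at 2.5 uM; on this read-out higher numbers stand for more inhibition of growth at the one concentration tested and lower numbers for less inhibition of growth.
Compound 2 `CS(=O)(=O)c1ccc(-c2cnc3[nH]cc(-c4nnc(-c5ccccc5)o4)c(=O)c3c2)cc1` gives 0.53% in this assay.
Compound 3 `O=c1c(-c2nnc(-c3ccc(F)cc3)o2)c[nH]c2ncc(-c3cccnc3)cc12` gives 9.87% in this assay.

Compound 2 stands at the lowest number of the three, yet its distances to compound 3 and to compound 1 both lie within the scatter, so the three compounds cannot be told apart on these numbers. Compound 4 `Cc1ccc(-c2nnc(-c3c[nH]c4ncc(-c5ccc(S(C)(=O)=O)cc5)cc4c3=O)o2)cc1` is compound 2 with one change: methyl in place of hydrogen on an aromatic carbon. Within the data shown here, no measured step involves this kind of change. Among the measured compounds shown here, the only measured step, a number 0.3 percentage points lower from compound 1 to compound 3 (within the scatter), alters a different part of the shared core and stays within the scatter. There is therefore no basis for expecting compound 4 to move beyond the scatter, and the expected step is a number 2.5 percentage points higher from compound 2 to compound 4 (within the scatter). For compound 4 the estimate is 3%, with a range from -6% to 14%.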

Compound 4, percent growth inhibition at one concentration: 7.47%
Compound 4: the middle estimate sits 4.5 percentage points below what was measured; low and high end bracket the measured number.
By their numbers in this assay, from the lowest: compounds 2, 4, 3 and 1 (each within the scatter of the next).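

Changing phenyl to 4-methylphenyl, on an aromatic carbon para to a large group, gives in this assay a step of a number 6.9 percentage points higher from compound 2 to compound 4 (within the scatter). Among these compounds, this is the first measured step at this position, and it shows that adding a methyl here leaves the number within the scatter, so compound 2 and compound 4 cannot be told apart. Nothing available explains the size of this step. From the compounds shown here alone, whether an amine, a carboxylic acid or a longer chain at this position would give a step beyond the scatter remains open.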